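Vinyl sulfone indoles: acetyl to cyano on the exocyclic alkene

A few compounds are considered here, and "the series" means these few. Any claim that something is new, unique, unknown or untested is made for them only; others in the source may bear on it.

Measured so far:
compound 1 `COc1ccc2[nH]c(-c3ccccc3)c(C=C(C#N)C#N)c2c1` gives 2100 nM in a functional assay on COLO 205 cells (Homo sapiens) for inhibition, read by sulforhodamine B assay, with a stated time of 48 h; on this read-out lower numbers stand for stronger inhibition of growth and higher numbers for weaker inhibition of growth;
compound 2 `CC(=O)/C(=C\c1c(-c2ccccc2)[nH]c2ccccc12)S(=O)(=O)c1ccccc1` gives 1700 nM in this assay.

Compound 2 carries the lowest of the two numbers in this assay, but compound 1 sits only a little higher, and that gap is within the usual scatter, so the two cannot be ordered. Both share the phenyl-substituted indole core with an electron-poor alkene attached; compound 1 differs in the methoxy on the core and in bearing two nitriles on the alkene rather than a sulfonyl and an acetyl.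

The next compound, compound 3 `N#C/C(=C\c1c(-c2ccccc2)[nH]c2ccccc12)S(=O)(=O)c1ccccc1`, is obtained from compound 2 by a single change: cyano in place of acetyl on a double-bonded chain carbon bound to a double-bonded chain carbon and a sulfonyl sulfur. Among the measured compounds shown here, no pair of measured compounds differs in just this place, so there is no directly comparable step. The nitrile-bearing alkene of compound 1 and the acetyl-bearing alkene of compound 2 give numbers within the scatter of one another, which points to a small step at most. The expected step from compound 2 to compound 3 in this assay is a 1.2-fold lower number from compound 2 to compound 3 (0.08 log units; within the scatter), not beyond the scatter in either direction. Compound 3 is therefore estimated at 1400 nM in this assay, with a range of 500 nM to 4000 nM.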

Compound 3, concentration for 50% growth inhibition: 1400 nM
Beside the measured number, compound 3's estimate shows no gap at the digits printed, within the range that was stated.
By their numbers in this assay, from the lowest: compounds 3, 2 and 1 (each within the scatter of the next).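

Among the compounds shown here, on a double-bonded chain carbon bound to a double-bonded chain carbon and a sulfonyl sulfur, cyano in place of acetyl gives a 1.2-fold lower number from compound 2 to compound 3 (0.08 log units; within the scatter) in this assay and supplies the first single-place reading at this position, which the earlier compounds could not offer. The exchange removes three heavy atoms and a double bond outside aromatic rings and brings in two heavy atoms and a triple bond, with the counts of hydrogen-bond donors and acceptors unchanged, and this read-out does not separate acetyl from cyano here. No measurement at hand bears on the reason for this result.

The compounds shown leave open whether the same holds at this carbon for groups of another kind, such as a carboxylic acid, an amine or a longer ketone chain. They also give no single-place reading for the methoxy on the core of compound 1 or for the sulfonyl group, so the part either plays in this assay remains unsettled.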